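The compounds below may be only part of what the source reports. "The series", "measured", "known", "first", "only" and "open" are said of these compounds alone.

In an assay on isolated protein for displacement of a labelled ligand from melanin-concentrating hormone receptor 1 (Homo sapiens) (on this read-out higher numbers stand for weaker inhibition and lower numbers for stronger inhibition), the three measured compounds stand as follows:

Compound 1, `CC(C)N(C)c1ccc2cc(NC(=O)CCc3ccc(C(F)(F)F)cc3)ccc2n1`: 2 nM
Compound 2, `NC1CCN(c2ccc3cc(NC(=O)CCc4ccc(C(F)(F)F)cc4)ccc3n2)C1`: 12 nM
Compound 3, `CC(=O)NC1CCN(c2ccc3cc(NC(=O)CCc4ccc(C(F)(F)F)cc4)ccc3n2)C1`: 5 nM

Compound 2 holds the highest number of the three. Its nearest neighbour is compound 3, reached by a 2.4-fold lower number from compound 2 to compound 3 (0.38 log units; beyond the scatter), and the furthest is compound 1, from which compound 2 is reached by a 6.0-fold higher number from compound 1 to compound 2 (0.78 log units; beyond the scatter). Compound 3 itself sits between them, reached from compound 1 by a 2.5-fold higher number from compound 1 to compound 3 (0.40 log units; beyond the scatter).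

Compound 4, `O=C(CCc1ccc(C(F)(F)F)cc1)Nc1ccc2nc(N3CCC3)ccc2c1`, is not yet measured. It differs from compound 2 in one place: azetidin-1-yl in place of 3-aminopyrrolidin-1-yl on an aromatic carbon.

Two of the measured steps bear on this change. Both the step from compound 1 to compound 2 and the step from compound 2 to compound 3 show that the shared core tolerates a range of substituents at this position, with the bare 3-aminopyrrolidin-1-yl of compound 2 giving the highest number. Compound 4 carries a small ring without a hydrogen-bond donor, closer in that respect to compound 1 than to compound 2, so a modest move to a lower number in this assay is expected, though a smaller one than the step from compound 1 to compound 2.

For compound 4 the estimate in this assay is therefore 4 nM, with a range from 1.5 nM to 10 nM, which corresponds to an expected step of a 3.0-fold lower number from compound 2 to compound 4 (0.48 log units; beyond the scatter).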

Compound 4, half-maximal inhibitory concentration: 4 nM
The estimate for compound 4 equals the measured number at the digits printed; measured number inside the range.
By their numbers in this assay, from the lowest: compounds 1, 4 and 3 (each within the scatter of the next, the first and the last beyond it); then compound 2.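

In this assay, compound 4 shows that this aromatic carbon next to the ring nitrogen accepts a four-membered ring with no substituent and no hydrogen-bond donor, and that leaving out the amine of 3-aminopyrrolidin-1-yl does not cost binding: the change gives a 3.0-fold lower number from compound 2 to compound 4 (0.48 log units; beyond the scatter). Compound 4 also cannot be told apart from its two other neighbours, with a 1.3-fold lower number from compound 3 to compound 4 (0.10 log units; within the scatter) and a 2.0-fold higher number from compound 1 to compound 4 (0.30 log units; within the scatter), so it joins compounds 1 and 3 as a replacement for the free amine of compound 2, which now stands beyond the scatter from all three, while compounds 1 and 3 remain beyond the scatter of each other. No measurement shown here accounts for these differences in the read-out.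

The step from compound 2 to compound 4 changes ring size and removes the amine at once, so its two parts remain unseparated; an unsubstituted pyrrolidin-1-yl would divide them. As far as these compounds go, whether the amine is tolerated on the four-membered ring also stays open, and 3-aminoazetidin-1-yl would put that question directly.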